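The compounds below may be only part of what the source reports. "The series", "measured", "known", "first", "only" and "open" are said of these compounds alone.

Compound 1 `CCCCCCCCCCc1cn(C(c2ccc(C#N)cc2)c2ccc(C#N)cc2)nn1` and compound 2 `N#Cc1ccc(OCc2cn(C(c3ccc(C#N)cc3)c3ccc(C#N)cc3)nn2)cc1` were both tested in an assay on isolated protein for inhibition of Aromatase (Homo sapiens), read by fluorescence and colorimetric assay, with a stated time of 30 min; a lower number here means a stronger inhibitor, a higher number a weaker inhibitor. Among the compounds with values here, compound 1 gives 16000 nM, while compound 2 gives 4640 nM, the lowest of the two numbers so far. Within the data shown here, the only measured step is a 3.4-fold lower number from compound 1 to compound 2 (0.54 log units; beyond the scatter). Compound 3 `Cc1ccc(OCc2cn(C(c3ccc(C#N)cc3)c3ccc(C#N)cc3)nn2)cc1` differs from compound 2 by methyl in place of cyano on an aromatic carbon, a change inside the group that entered in that one step. Among the measured compounds shown here, no measured step bears directly on this change, so only a small shift, if any beyond the scatter, is expected, a 1.5-fold higher number from compound 2 to compound 3 (0.18 log units; within the scatter). Compound 3 is therefore estimated at 7000 nM, with a range from 2500 nM to 20000 nM.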

Compound 3, half-maximal inhibitory concentration: 11000 nM
For compound 3 the middle estimate is 1.6-fold (0.20 log units) below the measured one; the range from low to high includes it.
By their numbers in this assay, from the lowest: compound 2; then compounds 3 and 1 (each within the scatter of the next).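

Methyl in place of cyano on this aromatic carbon gives a 2.4-fold higher number from compound 2 to compound 3 (0.37 log units; beyond the scatter), so the group at this position does affect the number in this assay. With methyl there, the 4-methylphenoxy compound no longer stands apart from the nonyl compound, with a 1.5-fold lower number from compound 1 to compound 3 (0.16 log units; within the scatter). Nothing here explains this shift.

Still open, from the compounds shown here alone, is where other groups at this position, such as an amine, a carboxylic acid or a chlorine atom, would fall relative to compound 2. Also open, going by these compounds, is whether the same change would have a similar effect on another aromatic carbon of this ring.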